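The source may hold more compounds than are shown below. What is called first, only, known or untested is meant among the compounds shown, and "the series" means these compounds.

Measured compounds:
compound 1, `COc1cc2ccc(=O)oc2cc1OCCCCOc1no[n+]([O-])c1S(=O)(=O)c1ccccc1`, 84.4%
compound 2, `COc1cc2ccc(=O)oc2cc1OCCCCCOc1c[n+]([O-])on1`, 87.1%
compound 3, `COc1cc2cc(NC(C)=O)c(=O)oc2cc1OCCOc1no[n+]([O-])c1S(=O)(=O)c1ccccc1`, 83.7%

In a functional assay on MCF7 cells (Homo sapiens) for inhibition, read by MTT assay, with a stated time of 48 h, tested at 10 uM (on this read-out lower numbers stand for less inhibition and higher numbers for more inhibition at the one concentration tested (going by the name of the read-out)), compound 1 gives 84.4%, the second highest of the three numbers. Its nearest neighbour is compound 3 at 83.7%, a value within the scatter of compound 1; the furthest is compound 2 at 87.1%, also within the scatter. For the measured compounds named here, the three measured compounds therefore cannot be told apart on this read-out, and no step between any pair of them is given.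

The unmeasured compound 4, `COc1cc2cc(N)c(=O)oc2cc1OCCCCOc1no[n+]([O-])c1S(=O)(=O)c1ccccc1`, differs from compound 1 in one place: amino in place of hydrogen on an aromatic carbon. Going by the values given here, the data offer no step that shows how a substituent entering at this carbon of the core affects this assay. Compound 3, which carries a larger group on the core, gives 83.7%, and this sits within the scatter of compound 1.

Compound 4 is therefore expected to behave much like compound 1, with a step of a number 0.4 percentage points lower from compound 1 to compound 4 (within the scatter) that is estimated to stay within the scatter. The expected value for compound 4 is 84%, with a range from 70% to 95%.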

Compound 4, a percentage reported as inhibition, at one concentration (the size of the read-out at that concentration, not a potency): 89%
The estimate for compound 4 lay 5 percentage points below the measured number; the range from low to high includes it.
By their numbers in this assay, from the lowest: compounds 3, 1, 2 and 4 (each within the scatter of the next).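

In this assay, for the compounds shown here, amino in place of hydrogen on an aromatic carbon of the shared core gives a number 4.6 percentage points higher from compound 1 to compound 4 (within the scatter), and this is the first step that isolates a change at this carbon. It shows that this carbon, two atoms from the ring oxygen, can carry an amino group without a shift that can be told from the scatter at the one concentration tested. The data at hand offer no explanation for this result and no measurement that bears on it.

The compounds shown leave open whether a hydroxyl, a methyl or a nitro group at this carbon would read the same way. They also leave open whether the amino group would keep this reading on a compound with a longer chain, and whether compound 1 and compound 4 would separate in a full concentration series.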